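This account rests on a few compounds, and the source may have more. Where it says the series, first, only, none or still open, it means among the compounds named here.

Working notes on the urea series. Compound 1 `COC(=O)c1cc(=O)c2cc(NC(=O)Nc3ccc(Cl)c(Cl)c3)ccc2[nH]1` and compound 2 `COC(=O)c1cc(=O)c2cc(NC(=O)Nc3cccc(C(C)=O)c3)ccc2[nH]1` share one core and differ only in the aryl group on the urea nitrogen. In a functional assay on SUP-B15 cells (Homo sapiens) for antiproliferative activity, with a stated time of 72 h (on this read-out lower numbers stand for an effect already at smaller amounts and higher numbers for an effect only at larger amounts of compound), compound 1 gives 5520 nM, and compound 2 gives 11400 nM. Among the compounds with values here, the step of a 2.1-fold higher number from compound 1 to compound 2 (0.31 log units; beyond the scatter) is the only measured one, so compound 2 stands as the higher of the two numbers, with compound 1 as its only neighbour.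

Compound 3 `COC(=O)c1cc(=O)c2cc(NC(=O)NCc3ccccc3)ccc2[nH]1` is not yet measured. It differs from compound 2 by benzyl in place of 3-acetylphenyl on an amide-type nitrogen. Within the data shown here, no measured step exchanges an aryl group for a benzyl group on that nitrogen; the step from compound 1 to compound 2 only swaps one substituted phenyl for another and was modest in size. On that slender basis no direction can be argued for, and a step in this assay of modest size at most, either way, is the expectation, with the number for compound 3 expected near that of compound 2 as a 1.1-fold lower number from compound 2 to compound 3 (0.06 log units; within the scatter). For compound 3 the expected value in this assay is 10000 nM, within the range 3000 nM to 35000 nM.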

Compound 3, half-maximal effective concentration: > 19500 nM
Compound 3 was reported as a limit; the forecaster's own chance of this, stated with the estimate: 20%; at least 1.9-fold (0.29 log units) between middle value and limit.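

In this assay compound 3 is held only as a limit and not as a number: the limit of > 19500 nM in this assay, at which 1 of the 3 values shown sits. Putting benzyl in place of 3,4-dichlorophenyl on the amide-type nitrogen gives an at least 3.5-fold higher number from compound 1 to compound 3 (0.54 log units; beyond the scatter), which shows that on this nitrogen an aryl group can be exchanged for benzyl with a loss beyond the scatter, a change the two aryl ureas alone could not show. Putting benzyl in place of 3-acetylphenyl gives an at least 1.7-fold higher number from compound 2 to compound 3 (0.23 log units; that floor lies within the scatter); that floor lies within the scatter, so the limit does not settle the order of these two compounds, and the benzyl urea is separated with confidence only from the 3,4-dichlorophenyl urea.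

Going by these compounds, how far the number for compound 3 lies past its limit remains unknown, and with the ring substituents and the ring's attachment changing together in both steps, the part each plays cannot be separated. Also open, on these data alone, is what an unsubstituted phenyl, a longer chain such as phenethyl, or a phenyl ring carrying an amine or a carboxylic acid would give on this nitrogen.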